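Cytotoxicity of triazole-linked cinnamic acids in lung cells

The source may hold more compounds than are shown below. What is called first, only, known or untested is meant among the compounds shown, and "the series" means these compounds.

Compound 1 `COc1ccc(-n2cc(COc3c(/C=C\C(=O)O)ccc(OC)c3CC=C(C)C)nn2)cc1` gives 10200 nM in a functional assay on A549 cells (Homo sapiens) for cytotoxicity, read by MTT assay, with a stated time of 24 h; a lower number here means a stronger inhibitor, a higher number a weaker inhibitor.
Compound 2 `COc1ccc(/C=C\C(=O)O)c(OCc2cn(-c3cccc([N+](=O)[O-])c3)nn2)c1CC=C(C)C` is recorded as "not determined" (no result reported) in this assay.

Compound 1 carries a methoxyphenyl group on the triazole and is a weak inhibitor in this assay. Compound 2 keeps the shared core and bears a nitrophenyl group on the triazole instead, but no result was reported for it, so compound 2 stands without a number and without any step that could be measured against compound 1.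

Compound 3 `COc1ccc(/C=C\C(=O)O)c(OCc2cn(-c3ccccc3C#N)nn2)c1CC=C(C)C` differs from compound 2 in one place: 2-cyanophenyl in place of 3-nitrophenyl on an aromatic nitrogen. For the measured compounds named here, with no measured step between any two compounds, the size and direction of this change in this assay cannot be read from the data; the only anchor is the value of compound 1, which shares the core and the triazole link.

On that basis compound 3 is expected to fall near the weak activity of compound 1, with an estimate of 10000 nM and a plausible range from 3000 nM to 40000 nM.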

Compound 3, half-maximal inhibitory concentration: 38600 nM
Compound 3: middle estimate off by 3.9-fold (0.59 log units), on the low side, and the stated range covers the measured number.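

For the compounds shown here, the change from 4-methoxyphenyl to 2-cyanophenyl on the aromatic nitrogen gives a 3.8-fold higher number from compound 1 to compound 3 (0.58 log units; beyond the scatter) in this assay, a modest step beyond the usual scatter that makes 2-cyanophenyl the weaker inhibitor of this pair and shows for the first time that this position responds to the group it carries. Compound 2 still has no number, and its step to compound 3 cannot be read, so the 3-nitrophenyl group adds nothing to this comparison. Nothing measured on these compounds accounts for the step, and the reason for it remains unknown.

On these data alone, the two measured compounds differ both in the group and in where it sits on the phenyl ring, so it remains open whether the step follows the nitrile itself or its place on that ring, and a 4-cyanophenyl group would be needed to separate the two. As far as these compounds go, it is also open how this position would respond to a plain phenyl group, or to a phenyl ring carrying an amine or a carboxylic acid, and whether any group here could give a stronger inhibitor than the 4-methoxyphenyl of compound 1.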